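Will compound 3 outlast compound 2?

The compounds below may be only part of what the source reports. "The series", "measured", "known", "first", "only" and "open" are said of these compounds alone.

- Compound 1 `O=C(Nc1ccc(F)c(Cl)c1)c1ccc(F)c(S(=O)(=O)N2CCOCC(O)C2)c1` – 4.63 h
- Compound 2 `O=C(Nc1ccc(F)c(Cl)c1)c1ccc(F)c(S(=O)(=O)N2CCCCC(O)CC2)c1` – 0.0833 h

In an ADME assay on cells (Hepatocyte, Homo sapiens) for metabolic stability (on this read-out lower numbers stand for a shorter-lived compound and higher numbers for a longer-lived compound), compound 2 holds the lower of the two numbers (0.0833 h). Still unmeasured, compound 3 `CC1(O)COCCN(S(=O)(=O)c2cc(C(=O)Nc3ccc(F)c(Cl)c3)ccc2F)C1` differs from compound 2 in one place (a group of 9 heavy atoms (6 carbon, 1 nitrogen, 2 oxygen; one seven-membered non-aromatic ring with 2 hetero atoms) in place of a group of 9 heavy atoms (7 carbon, 1 nitrogen, 1 oxygen; one eight-membered non-aromatic ring with 1 hetero atom), on a sulfonyl sulfur). The entering group is 6-hydroxy-6-methyl-1,4-oxazepan-4-yl, which has a seven-membered non-aromatic ring with 2 hetero atoms, as the group in compound 1 does. For the measured compounds named here, one measured step bears on this change, and it runs the opposite way (a 56-fold lower number from compound 1 to compound 2 (1.74 log units; beyond the scatter)). That step was large and beyond the scatter, so a large rise in this assay is expected. Going by the values given here, no measured step shows what the added methyl does, which keeps the range wide. The expected step is large (a 48-fold higher number from compound 2 to compound 3 (1.68 log units; beyond the scatter)). Compound 3 is estimated at 4 h within a range from 1.2 h to 12 h (an expectation only).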

Compound 3, half-life: 1.28 h
For compound 3 the middle estimate is 3.1-fold (0.49 log units) above the measured one, and the stated range covers the measured number.
By their numbers in this assay, from the lowest: compound 2; then compound 3; then compound 1.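

In this assay, the methyl group now has a measured effect: methyl in place of hydrogen on a saturated ring carbon gives a modest change that is still beyond the scatter (a 3.6-fold lower number from compound 1 to compound 3 (0.56 log units; beyond the scatter)). Even with that methyl, the 6-hydroxy-6-methyl-1,4-oxazepan-4-yl group on the sulfonyl sulfur keeps a large lead over the eight-membered ring of compound 2 (a 15-fold higher number from compound 2 to compound 3 (1.19 log units; beyond the scatter)). Nothing available explains either step.

The compounds shown leave open whether this shift is particular to methyl or would also appear with another group on that ring carbon, such as ethyl or fluorine. They also leave open how much the hydroxyl group contributes, a question that a ring carrying methyl alone at that carbon could answer.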